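This account rests on a few compounds, and the source may have more. Where it says the series, first, only, none or still open, it means among the compounds named here.

Compound 1 `CC(C)c1nn(-c2ccc(C(N)=O)c(N[C@H]3CC[C@H](O)CC3)c2)c2nccc(-n3cnc(-c4cncnc4)c3)c12` was tested in a functional assay on SK-BR-3 cells (Homo sapiens) for inhibition, read by CellTiter-Glo, with a stated time of 72 h (on this read-out higher numbers stand for weaker inhibition and lower numbers for stronger inhibition), where compound 1 gives 387 nM. Within the data shown here, this is the higher of the two numbers recorded: the other compound, compound 2 `CC(C)c1nn(-c2ccc(C(N)=O)c(N[C@H]3CC[C@H](O)CC3)c2)c2cccc(-c3cnc4ccccc4c3)c12`, gives 39 nM in this assay, a lower number that lies beyond the usual scatter, but compound 2 differs from compound 1 in more than one place, so no single structural step links them.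

Compound 3 `CC(C)c1nn(-c2ccc(C(N)=O)c(N[C@H]3CC[C@H](O)CC3)c2)c2nccc(-n3cnc(-c4ccccc4)c3)c12` is the next compound, not yet measured. It differs from compound 1 in one place only: phenyl in place of pyrimidin-5-yl on an aromatic carbon. The pyrimidin-5-yl that leaves carries two hydrogen-bond acceptors; the phenyl that enters carries none. Among the measured compounds shown here, no measured pair here isolates this change, so the expected step is small: a change from compound 1 to compound 3 of about a 1.5-fold lower number from compound 1 to compound 3 (0.19 log units; within the scatter) in this assay, a shift that is expected to stay roughly within the usual scatter. On that basis compound 3 is estimated at 250 nM, with a plausible range from 80 nM to 800 nM.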

Compound 3, half-maximal inhibitory concentration: 276 nM
Estimate against measurement, compound 3: 1.1-fold (0.04 log units) below; low and high end bracket the measured number.
By their numbers in this assay, from the lowest: compound 2; then compounds 3 and 1 (each within the scatter of the next).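

In this assay, putting phenyl in place of pyrimidin-5-yl on this aromatic carbon of the five-membered ring gives a 1.4-fold lower number from compound 1 to compound 3 (0.15 log units; within the scatter), so the two compounds cannot be told apart on this read-out. At this position, then, a six-membered aromatic ring of carbon only, with no hydrogen-bond acceptors, serves as well as one with two ring nitrogens and two hydrogen-bond acceptors, at least on this core. No measurement available here accounts for this result.

The compounds shown compare only these two six-membered aromatic rings here, so the effect of a carboxylic acid, a morpholine or a longer alkyl chain at this position stays open. They also leave open whether the same swap would give so small a step on a different core.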